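This account rests on a few compounds, and the source may have more. Where it says the series, first, only, none or still open, it means among the compounds named here.

Compound 1 `NC1=NC2(CCOCC2)N(OCCCOc2ccccc2Cl)C(N)=N1` gives 660 nM
Compound 2 `NC1=NC2(CCOCC2)N(OCCCOc2ccc(Cl)cc2Cl)C(N)=N1` gives 330 nM
Compound 3 `NC1=NC2(CCOCC2)N(OCCCOc2ccccc2Br)C(N)=N1` gives 610 nM

These three numbers come from a functional assay on HL-60 cells (Homo sapiens) for antiproliferative activity, read by MTT assay, with a stated time of 72 h (on this read-out higher numbers stand for weaker inhibition and lower numbers for stronger inhibition), and lie close together. Compound 3 stands within the scatter of both other compounds, so no ranking among the three can be claimed.

The next compound, compound 4 `NC1=NC2(CCOCC2)N(OCCCOc2cccc(Br)c2)C(N)=N1`, has the same atoms as compound 3, joined differently: 3-bromophenyl in place of 2-bromophenyl on an oxygen on a saturated carbon.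

Among the measured compounds shown here, no measured pair makes this exact move, so the evidence is indirect. The closest guides are three changes to the same aromatic group. Bromo in place of chloro gave a 1.1-fold lower number from compound 1 to compound 3 (0.03 log units; within the scatter) and an added chloro gave a 2.0-fold lower number from compound 1 to compound 2 (0.30 log units; within the scatter) while the remaining pair shows a 1.8-fold higher number from compound 2 to compound 3 (0.27 log units; within the scatter) in the same read-out. All three steps stay within the scatter, so across these compounds the aromatic changes have barely registered. Whether that holds when the bromo group changes place is untested, and the range is kept wide for that reason.

The expected result is therefore no shift beyond the scatter, and the estimated step is a 1.0-fold lower number from compound 3 to compound 4 (0.01 log units; within the scatter) in this assay for this change. For compound 4 the estimated value is 600 nM with an expected range from 250 nM to 1400 nM in this read-out.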

Compound 4, half-maximal inhibitory concentration: 560 nM
Compound 4: middle estimate off by 1.1-fold (0.03 log units), on the high side, within the range that was stated.
By their numbers in this assay, from the lowest: compounds 2, 4, 3 and 1 (each within the scatter of the next).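

Moving the bromo group, with 3-bromophenyl in place of 2-bromophenyl on an oxygen on a saturated carbon, rearranges the same atoms without adding or removing any, and in this assay it gives a 1.1-fold lower number from compound 3 to compound 4 (0.04 log units; within the scatter) within a set of compounds that had so far varied only in which halogen was present and how many. Within this small set, then, the place of the bromo group on the aromatic ring makes no difference that can be told apart from the scatter of repeated measurements. Compound 4 also stays within the scatter of both chlorinated compounds, with a 1.7-fold higher number from compound 2 to compound 4 (0.23 log units; within the scatter) and with a 1.2-fold lower number from compound 1 to compound 4 (0.07 log units; within the scatter) in the same read-out, and nothing available here accounts for this lack of separation.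

All the aromatic groups shown carry only chloro or bromo, so it remains open whether an amine or a carboxylic acid on that ring would leave the number just as unmoved. From the compounds shown here alone, the three-carbon link and the shared core are also the same throughout, so a longer chain between the core and the phenoxy group is an equally open question.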